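One Methoxy Step Measured Once, Expected Again

This account rests on a few compounds, and the source may have more. Where it says the series, first, only, none or still open, it means among the compounds named here.

Compound 1, `C=C(Br)C(=O)Nc1ccc(C(=O)/C=C/c2ccccc2)cc1`: in a functional assay on L1210 cells (Mus musculus) for antiproliferative activity, with a stated time of 48 h (on this read-out higher numbers stand for weaker inhibition and lower numbers for stronger inhibition), compound 1 gives 880 nM.
Compound 2, `C=C(Br)C(=O)Nc1ccc(C(=O)/C=C/c2ccc(OC)cc2)cc1`: in this assay compound 2 gives 900 nM.
Compound 3, `COc1ccccc1/C=C/C(=O)c1ccc(N)cc1`: in this assay compound 3 gives 12000 nM.

Compounds 1 and 2 share one core, and the single difference between them is methoxy in place of hydrogen on an aromatic carbon. The step that this change made is a 1.0-fold higher number from compound 1 to compound 2 (0.01 log units; within the scatter). Compound 3 stands on a different core; the difference between the two cores is not broken down here. Its value stands well apart from the other two, the nearest of them being compound 2.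

Compound 4, `COc1cccc(/C=C/C(=O)c2ccc(N)cc2)c1OC`, has not yet been measured. It differs from compound 3 by methoxy in place of hydrogen on an aromatic carbon. Within the data shown here, this is the same kind of change as the one from compound 1 to compound 2, but not the same: in the measured pair the entering methoxy sits para to a large group, whereas in compound 4 it sits ortho to a methoxy group and meta to a large group.

In this assay the step from compound 3 to compound 4 is expected to be no change at the digits printed from compound 3 to compound 4 (within the scatter), close to the earlier one, because a 1.0-fold higher number from compound 1 to compound 2 (0.01 log units; within the scatter) showed the methoxy change leaving the number essentially where it was. The estimate for compound 4 in this assay is 12000 nM, with a range from 4000 nM to 36000 nM.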

Compound 4, half-maximal inhibitory concentration: 13000 nM
Compound 4: the middle estimate sits 1.1-fold (0.03 log units) below what was measured; measured number inside the range.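

Set beside the earlier step, the new one in this assay, a 1.1-fold higher number from compound 3 to compound 4 (0.03 log units; within the scatter), tells the same story, and the two steps do not differ: the same change on two cores in this assay, a 1.0-fold higher number (0.01 log units; within the scatter) from compound 1 to compound 2 and a 1.1-fold higher number (0.03 log units; within the scatter) from compound 3 to compound 4, 1.1-fold (0.03 log units) apart, within the scatter of two such steps. Among these compounds, on these two cores, then, methoxy in place of hydrogen on an aromatic carbon left the number where it was, even though in compound 4 the entering methoxy stands ortho to a methoxy group and meta to a large group, a different place from the one it takes in compound 2. Among the compounds shown here, this does not show that the change is without effect on every core or at every place on the ring, as it rests on only two pairs in a single assay, and neither pair shows what the change would do on one core at the place it takes on the other.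

The compounds shown leave open whether a different group at these places, such as a hydroxyl, an ethoxy group or a fluorine atom, would shift the number as methoxy did not. They also leave open which part of the difference between the core of compound 1 and the core of compound 3 goes with the gap between their numbers, as that difference is not broken down into single changes.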